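Trading a difluorophenyl for cyclopropyl on a weak scaffold

The compounds below may be only part of what the source reports. "The series", "measured", "known", "first", "only" and "open" are said of these compounds alone.

Measured compounds:
compound 1, `O=C1O[C@H]([C@@H](O)Cn2cc(-c3cc(F)cc(F)c3)nn2)C(OCc2ccccc2)=C1OCc1ccccc1`: 48200 nM
compound 2, `CC(C)(C)OC(=O)N1CCN(C(=S)SCc2cn(C[C@H](O)[C@H]3OC(=O)C(OCc4ccccc4)=C3OCc3ccccc3)nn2)CC1`: > 100000 nM
compound 3, `COc1ccccc1-c1cn(C/C=C2\OC(=O)C(OCc3ccccc3)=C2OCc2ccccc2)nn1`: > 100000 nM

Of the compounds shown here, three sharing the same lactone core have been tested in a functional assay on HCT-116 cells (Homo sapiens) for antiproliferative activity, read by MTT assay, with a stated time of 72 h; on this read-out lower numbers stand for stronger inhibition and higher numbers for weaker inhibition. For the measured compounds named here, compound 1 gives 48200 nM, the only actual number among the three. Compound 2 gives > 100000 nM, which is a limit of the assay rather than a number. Compound 3 likewise gives > 100000 nM, again a limit. So compound 1 stands alone as the one measured value, while the other two sit at the limit of > 100000 nM in this assay, at which 2 of the 3 values shown sit. No pair of these compounds differs in just one place, so no single step can be read from them.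

Compound 4, `O=C1O[C@H]([C@@H](O)Cn2cc(C3CC3)nn2)C(OCc2ccccc2)=C1OCc1ccccc1`, has not yet been measured in this assay. It differs from compound 1 only as follows: cyclopropyl in place of 3,5-difluorophenyl on an aromatic carbon. Going by the values given here, there is no measured step to lean on, so the expectation rests on compound 1 alone, whose value of 48200 nM already lies close to the weak end of what the assay resolves. The step from compound 1 to compound 4 is expected to be a 1.6-fold higher number from compound 1 to compound 4 (0.19 log units; within the scatter), modestly toward weaker inhibition, possibly not beyond the scatter. Compound 4 is therefore estimated at 75000 nM, within 25000 nM to 200000 nM.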

Compound 4, half-maximal inhibitory concentration: 30400 nM
Compound 4: the middle estimate sits 2.5-fold (0.39 log units) above what was measured, and the stated range covers the measured number.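

Until now, no single change could be read at this place, an aromatic carbon of a five-membered aromatic ring with 3 nitrogen; in this assay, the replacement of 3,5-difluorophenyl by cyclopropyl now gives a 1.6-fold lower number from compound 1 to compound 4 (0.20 log units; within the scatter). This step removes the six-membered aromatic ring and both fluorine atoms, and the group at this place shrinks from 8 heavy atoms to 3, yet the two compounds cannot be told apart on this read-out. Compound 4 also gives a true number, 30400 nM, rather than a limit, so for this pair neither the aromatic ring nor the fluorine atoms are needed for the weak activity seen here.

Going by these compounds, with only these two groups compared at this place, it remains open whether any other group, such as an aminomethyl group, a carboxylic acid or a longer chain like n-butyl, would move the value beyond the scatter in either direction. Any further loss of activity could be followed only over a short stretch of the scale: the limit of > 100000 nM in this assay, at which 2 of the 4 values shown sit.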